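A few compounds are considered here, and "the series" means these few. Any claim that something is new, unique, unknown or untested is made for them only; others in the source may bear on it.

Measured in a functional assay on cells (Endothelial cell, Bos taurus) for antiproliferative activity; on this read-out higher numbers stand for weaker inhibition and lower numbers for stronger inhibition:
- Compound 1 `COc1ccc(/C=C(/F)c2cc(OC)c(OC)c(OC)c2)cc1O`: 1700 nM
- Compound 2 `COc1ccc(/C=C(/F)c2cc(OC)c(OC)c(OC)c2)cc1[N+](=O)[O-]`: 38400 nM

Compound 2 holds the higher of the two numbers, so it is the weaker inhibitor of the pair. Going by the values given here, the single measured step, a 23-fold higher number from compound 1 to compound 2 (1.35 log units; beyond the scatter), is large and lies beyond the scatter. Compound 3 `COc1ccc(/C=C(\F)c2cc(OC)c(OC)c(OC)c2)cc1[N+](=O)[O-]` is the next to be read in this assay, and it departs from compound 2 in one respect: the two compounds have the same atoms and bonds and differ only in configuration as drawn: 1 of 1 stereo elements differ; a double bond is drawn E in compound 2 and Z in compound 3.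

That step offers only limited guidance. It records nitro in place of hydroxy on an aromatic carbon, whereas compound 2 and compound 3 carry the same groups. Among the compounds with values here, no pair differing only in the configuration of the double bond has been measured, so the size and direction of this change remain unknown. The large measured step shows only that this small set can shift considerably with a single change. With nothing to set a direction, no step beyond the scatter is expected, and the estimated change is a 1.1-fold higher number from compound 2 to compound 3 (0.04 log units; within the scatter). The range is kept wide on both sides. For compound 3 the expected value is 42000 nM, with an estimated range of 12000 nM to 150000 nM.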

Compound 3, half-maximal inhibitory concentration: 2800000 nM
Compound 3: the middle estimate sits 67-fold (1.82 log units) below what was measured; the whole stated range lies below it.
By their numbers in this assay, from the lowest: compound 1; then compound 2; then compound 3.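

In this assay the configuration of the double bond proves to be a strong determinant in its own right, a point the earlier pair could not address, since it showed only a change of group. The new result, a 73-fold higher number from compound 2 to compound 3 (1.86 log units; beyond the scatter) with the nitro group held in place, is a large step, so that a change of configuration alone can move the number about as visibly as the earlier exchange of hydroxy for nitro, which gave a 23-fold higher number from compound 1 to compound 2 (1.35 log units; beyond the scatter) in the same assay. Within this pair the E form, compound 2, is the stronger inhibitor, and the gap can be assigned to the double bond alone because nothing else separates the two: the fact that compounds 2 and 3 differ only in the configuration as drawn.

The compounds shown leave open whether the configuration step keeps its direction and size with hydroxy in place of nitro, as in compound 1. They also leave open where an amine on that same aromatic carbon would fall, and whether it would respond to the configuration of the double bond in the same way.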